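The source may hold more compounds than are shown below. What is called first, only, known or untested is meant among the compounds shown, and "the series" means these compounds.

The series is read in a functional assay on DU-145 cells (Homo sapiens) for antiproliferative activity, with a stated time of 48 h; on this read-out lower numbers stand for stronger inhibition of growth and higher numbers for weaker inhibition of growth. Compound 1 `Cc1cc(O)c(C2=NN(c3ccc(S(N)(=O)=O)cc3)C(c3ccccc3O)C2)cc1Cl` gives 2410 nM in this assay, compound 2 `Cc1cc(O)c(C2=NN(c3ccc(S(N)(=O)=O)cc3)C(c3ccccc3Cl)C2)cc1Cl` gives 2010 nM, and compound 3 `COc1ccc(C2CC(c3cc(Cl)c(C)cc3O)=NN2c2ccc(S(N)(=O)=O)cc2)cc1OC` gives 4490 nM. Compound 3 holds the highest of the three numbers; the gap a 1.9-fold higher number from compound 1 to compound 3 (0.27 log units; within the scatter) separates it from compound 1, and the gap a 2.2-fold higher number from compound 2 to compound 3 (0.35 log units; beyond the scatter), a modest one, separates it from compound 2. Between the first two compounds the step of a 1.2-fold lower number from compound 1 to compound 2 (0.08 log units; within the scatter) turns on a single group at one aromatic carbon.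

Compound 4 `COc1ccc(C2CC(c3cc(Cl)c(C)cc3O)=NN2c2ccc(S(N)(=O)=O)cc2)c(OC)c1OC` differs from compound 3 by methoxy in place of hydrogen on an aromatic carbon; read one bond further out, 3,4-dimethoxyphenyl becomes 2,3,4-trimethoxyphenyl. Going by the values given here, no measured step adds a methoxy group to a ring that already carries two. Among the compounds with values here, the steps that come closest exchange the whole aryl group on the saturated ring carbon, and the only one-group step stayed within the scatter. Compound 4 is therefore expected to move by a 1.1-fold higher number from compound 3 to compound 4 (0.05 log units; within the scatter) in this assay, a shift unlikely to exceed the scatter. The estimate for compound 4 is 5000 nM, with a range from 2500 nM to 10000 nM.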

Compound 4, concentration for 50% growth inhibition: 3400 nM
Beside the measured number, compound 4's estimate is 1.5-fold (0.17 log units) above it, and the stated range covers the measured number.
By their numbers in this assay, from the lowest: compounds 2, 1, 4 and 3 (each within the scatter of the next, the first and the last beyond it).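

In this assay, the step of a 1.3-fold lower number from compound 3 to compound 4 (0.12 log units; within the scatter) shows that this position, ortho to a large group and to a methoxy group, takes a further methoxy group with no change beyond the scatter, the first single-group addition read on this ring. The two exchanges of the whole aryl group, a 1.7-fold higher number from compound 2 to compound 4 (0.23 log units; within the scatter) and a 1.4-fold higher number from compound 1 to compound 4 (0.15 log units; within the scatter), also stay within the scatter, so the 2,3,4-trimethoxyphenyl group does not carry the gap beyond the scatter printed for the 3,4-dimethoxyphenyl group against the 2-chlorophenyl group. Nothing given here bears on the reason for these numbers.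

The compounds shown leave open whether a longer chain such as ethoxy, or an amine or a carboxylic acid, at this same position would move the number beyond the scatter. They also leave open how a methoxy group at this position would read on a ring without the other two methoxy groups.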